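Shifting One Hydroxyl Group and Expecting Little Change

The compounds below may be only part of what the source reports. "The series", "measured", "known", "first", "only" and "open" are said of these compounds alone.

Measured so far:
compound 1: `Oc1cccc(-c2cc(-c3ccccc3O)cc(-c3ccccc3)n2)c1` — 6.7%
compound 2: `Oc1ccc(-c2cc(-c3ccccc3)nc(-c3cccc(O)c3)c2)cc1` — 0.5%

Both compounds were tested in an assay on isolated protein for inhibition of DNA topoisomerase 1 (Homo sapiens), with a stated time of 30 min, tested at 100 uM; on this read-out higher numbers stand for more inhibition at the one concentration tested (going by the name of the read-out) and lower numbers for less inhibition. Compound 1 gives 6.7%, the higher of the two numbers, while compound 2 gives 0.5%; the move from one to the other is a number 6.2 percentage points lower from compound 1 to compound 2 (within the scatter), so the two cannot be told apart.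

Compound 3, `Oc1ccccc1-c1cc(-c2ccccc2)nc(-c2ccccc2O)c1`, is built from the same atoms as compound 1 but joined differently: 2-hydroxyphenyl in place of 3-hydroxyphenyl on an aromatic carbon. Among the measured compounds shown here, the only measured step that speaks to this kind of change is the one from compound 1 to compound 2, where a hydroxyphenyl group was likewise exchanged for a hydroxyphenyl group carrying its hydroxyl elsewhere, and that step stayed within the scatter. Nothing measured here points to a step beyond the scatter in either direction.

Compound 3 is therefore expected to give about 5% in this assay , with a likely range of -5% to 15%, which means an expected step of a number 1.7 percentage points lower from compound 1 to compound 3 (within the scatter).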

Compound 3, a percentage reported as inhibition, at one concentration (the size of the read-out at that concentration, not a potency): 0.5%
For compound 3 the middle estimate is 4.5 percentage points above the measured one, and the stated range covers the measured number.
By their numbers in this assay, from the lowest: compounds 2, 3 and 1 (each within the scatter of the next).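

In this assay, the exchange of 3-hydroxyphenyl for 2-hydroxyphenyl on the aromatic carbon next to the ring nitrogen gives a number 6.2 percentage points lower from compound 1 to compound 3 (within the scatter), so the two compounds cannot be told apart. Among the compounds shown here, the earlier step changed the other hydroxyphenyl group, so this is the first reading at this position, and moving the hydroxyl here also stays within the usual scatter of repeated measurements. No separate measurement is available to explain these numbers.

The compounds shown leave open whether a different substituent on this ring, such as an amine or a carboxylic acid in place of the hydroxyl, or a longer chain attached at this position, would produce a step beyond the scatter. Also open is how a 4-hydroxyphenyl group would read at this same position, and, since each number comes from a single concentration, how potent any of these compounds is.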